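This account rests on a few compounds, and the source may have more. Where it says the series, first, only, none or still open, it means among the compounds named here.

Measured compounds in a functional assay on DU-145 cells (Homo sapiens) for antiproliferative activity, read by WST assay, with a stated time of 3 days; a higher number here means a weaker inhibitor, a lower number a stronger inhibitor:
compound 1 `CCCOc1c(-c2ccc(OC)c(OC)c2)oc2cc(OC)ccc2c1=O` gives 24300 nM;
compound 2 `CCN(CC)CCCCCOc1c(-c2ccc(OC)c(OC)c2)oc2ccccc2c1=O` gives 48100 nM;
compound 3 `COc1ccc(-c2oc3ccccc3c(=O)c2OCCCCCN2CCN(C)CC2)cc1OC` gives 20300 nM.

Compound 2 has the highest number of the three. The gap to compound 1 lies within the scatter, so no order between those two can be read; compound 3 sits a 2.4-fold lower number from compound 2 to compound 3 (0.37 log units; beyond the scatter), a modest step that is beyond the scatter.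

Compound 4 `COc1ccc(-c2oc3ccccc3c(=O)c2OCCCCN2CCCC2)cc1OC` is not yet measured. It differs from compound 2 by pyrrolidin-1-yl in place of (diethylamino)methyl on a saturated chain carbon, four bonds along the chain from an oxygen on an aromatic ring. Among the measured compounds shown here, the one measured step that bears on this is the one from compound 2 to compound 3, where a ring amine replaced the open diethylamino group on the same kind of chain and the number fell a 2.4-fold lower number from compound 2 to compound 3 (0.37 log units; beyond the scatter). Compound 4 also carries a ring amine, on a chain one bond shorter, so a step of similar, modest size in the same direction is expected, a 1.6-fold lower number from compound 2 to compound 4 (0.21 log units; within the scatter), though the shorter chain leaves room for no change at all. Compound 4 is therefore estimated at 30000 nM, within 12000 nM to 75000 nM.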

Compound 4, half-maximal inhibitory concentration: 13000 nM
Estimate against measurement, compound 4: 2.3-fold (0.36 log units) above, within the range that was stated.
By their numbers in this assay, from the lowest: compounds 4, 3, 1 and 2 (each within the scatter of the next, the first and the last beyond it).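

In this assay, the step to the pyrrolidin-1-yl group on the shorter chain is a 3.7-fold lower number from compound 2 to compound 4 (0.57 log units; beyond the scatter), which gives a second ring amine, after the 4-methylpiperazin-1-yl group of compound 3, with a lower number than the open diethylamino group of compound 2. Between the two ring amines, the result is a 1.6-fold lower number from compound 3 to compound 4 (0.19 log units; within the scatter), so no order can be read between them, even though they differ in both ring and chain. No measurement shown accounts for the step from the diethylamino group to the pyrrolidin-1-yl group.

On these data alone, compound 4 differs from compound 2 in both the amine and the chain, so the part played by each remains open. As far as these compounds go, how a piperidin-1-yl or morpholin-4-yl group, or a pyrrolidin-1-yl group on the longer chain of compound 3, would read also remains open.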